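Swapping an octyloxy chain for a hexyl chain

The compounds below may be only part of what the source reports. "The series", "measured", "known", "first", "only" and "open" are said of these compounds alone.

Compound 1 `CCCCCCCCOc1ccc(C(=O)N/N=C/c2ccc([N+](=O)[O-])o2)cc1` is the starting point. In an ADME assay on U2OS cells (Homo sapiens) for cytotoxicity (a higher number here means that more compound is tolerated, a lower number that less compound is tolerated), compound 1 gives > 200000 nM, which is a limit of the assay and not a number. This places compound 1 at the limit of > 200000 nM in this assay, at which 1 of the 2 values shown sits. Compound 2 `O=C(N/N=C/c1ccc([N+](=O)[O-])o1)c1ccc2ccccc2c1` gives 64200 nM in this assay. Compound 3 `CCCCCCc1ccc(C(=O)N/N=C/c2ccc([N+](=O)[O-])o2)cc1` has not been measured yet; it differs from compound 1 by hexyl in place of octyloxy on an aromatic carbon. Going by the values given here, no measured step of this kind exists here, so the expected step is a modest one downward, an at least 1.3-fold lower number from compound 1 to compound 3 (0.12 log units; that floor lies within the scatter). Compound 3 is therefore estimated at 150000 nM in this assay, within 50000 nM to 200000 nM.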

Compound 3, half-maximal cytotoxic concentration: > 200000 nM
Compound 3 gave a limit, no number (the forecaster's own chance of this, stated with the estimate: 50%); at least 1.3-fold (0.12 log units) between middle value and limit.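

Compound 1 and compound 3 both give only a limit and not a number, so the step between them cannot be read. As far as these compounds go, how much compound each tolerates, and whether hexyl in place of octyloxy changes that, stays open.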